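Exchanging the Benzyl Aryl Group of Compound 2

This account rests on a few compounds, and the source may have more. Where it says the series, first, only, none or still open, it means among the compounds named here.

Of the compounds shown here, three have been measured in an assay on isolated protein for inhibition of Amine oxidase [flavin-containing] B (Homo sapiens), read by fluorescence and Amplex Red, with stated times of 15 min and 20 min; on this read-out higher numbers stand for weaker inhibition and lower numbers for stronger inhibition. Compound 1 `C#CCN(CCCCOc1ccc2ccc(=O)oc2c1)Cc1cccc(OC)c1` gives 2340 nM, compound 2 `C#CCN(CCCOc1ccc2ccc(=O)oc2c1)Cc1ccc(OC)cc1` gives 6080 nM, and compound 3 `C#CCN(CCCCOc1ccc2ccc(=O)oc2c1)Cc1ccc(C(C)C)cc1` gives 3500 nM. Compound 2 stands highest of the three numbers; its gap to compound 3 lies within the scatter, while its gap to compound 1 lies beyond it.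

Compound 4 `C#CCN(CCCOc1ccc2ccc(=O)oc2c1)Cc1ccc(F)c(F)c1` differs from compound 2 by 3,4-difluorophenyl in place of 4-methoxyphenyl on a saturated chain carbon bound to an amine nitrogen. For the measured compounds named here, only one measured step changes a single place, and it exchanges the aryl group on the same saturated chain carbon bound to an amine nitrogen: a 1.5-fold higher number from compound 1 to compound 3 (0.17 log units; within the scatter). That step was small, so an aryl exchange at this place has so far moved the number little. Going by the values given here, no measured pair carries a fluorinated aryl group, and compound 2 and compound 4 share a shorter chain than compound 1 and compound 3, so the step is read as a guide only.

Compound 4 is therefore expected to give about 5000 nM, with a range from 2000 nM to 12000 nM. The expected step is a 1.2-fold lower number from compound 2 to compound 4 (0.08 log units; within the scatter), within the scatter.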

Compound 4, half-maximal inhibitory concentration: 4860 nM
For compound 4 the middle estimate is 1.0-fold (0.01 log units) above the measured one, and the stated range covers the measured number.
By their numbers in this assay, from the lowest: compounds 1, 3, 4 and 2 (each within the scatter of the next, the first and the last beyond it).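

In this assay, the exchange of 4-methoxyphenyl for 3,4-difluorophenyl on a saturated chain carbon bound to an amine nitrogen gives a 1.3-fold lower number from compound 2 to compound 4 (0.10 log units; within the scatter), so this place now shows a second aryl exchange that stays within the scatter, beside a 1.5-fold higher number from compound 1 to compound 3 (0.17 log units; within the scatter). The new pair adds a fluorinated aryl group and shows that the entering group, with 0 hydrogen-bond acceptors against 1 in the group that leaves, brings no step beyond the scatter on the chain of compound 2. No measurement shown here gives a reason for this result.

Going by these compounds, it remains open whether 3,4-difluorophenyl would read the same on a longer chain. On these data alone, it also remains open whether a pyridine ring or a carboxylic acid on the aryl ring would move the number beyond the scatter at this place.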